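A few compounds are considered here, and "the series" means these few. Any claim that something is new, unique, unknown or untested is made for them only; others in the source may bear on it.

Measured in an assay on HEK293 cells for displacement of a labelled ligand from growth hormone secretagogue receptor type 1 (Homo sapiens), with a stated time of 60 min; on this read-out higher numbers stand for weaker inhibition and lower numbers for stronger inhibition:
compound 1 `Cc1ncccc1-c1nc2cn(-c3ccccc3)nc2c(=O)n1C[C@H]1CCCN(C[C@H]2CCCO2)C1` — 190 nM
compound 2 `COc1cccc(-n2cc3nc(-c4cccnc4C)n(C[C@H]4CCCN(CC5CCCCO5)C4)c(=O)c3n2)c1` — 120 nM
compound 3 `Cc1ncccc1-c1nc2cn(-c3cccc(OC(C)C)c3)nc2c(=O)n1C[C@H]1CCCN(C[C@H]2CCCO2)C1` — 11 nM

Compound 2 stands second highest of the three numbers in this assay; its value lies within the scatter of compound 1, while compound 3 sits below it, beyond the scatter. Going by the values given here, the only single-point step measured, a 17-fold lower number from compound 1 to compound 3 (1.24 log units; beyond the scatter), concerns a group on an aromatic carbon.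

Among the compounds with values here, compound 4 `COc1cccc(-n2cc3nc(-c4cccnc4C)n(C[C@H]4CCCN(CC(C)C)C4)c(=O)c3n2)c1` differs from compound 2 on a saturated chain carbon bound to an amine nitrogen in a ring: isopropyl in place of oxan-2-yl on a saturated chain carbon bound to an amine nitrogen in a ring No measured pair varies this site, so the step from compound 1 to compound 3 does not bear on it. With nothing to go on there, no step beyond the scatter is expected in this assay, no change at the digits printed from compound 2 to compound 4 (within the scatter). Compound 4 is therefore estimated at 120 nM, within 40 nM to 400 nM.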

Compound 4, half-maximal inhibitory concentration: 5.7 nM
Compound 4: middle estimate off by 21-fold (1.32 log units), on the high side, outside the stated range (below it).
By their numbers in this assay, from the lowest: compounds 4 and 3 (each within the scatter of the next); then compounds 2 and 1 (each within the scatter of the next).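

The group on the saturated chain carbon bound to an amine nitrogen in a ring strongly affects the result in this assay: isopropyl in place of oxan-2-yl gives a 21-fold lower number from compound 2 to compound 4 (1.32 log units; beyond the scatter). This is the only step shown at this site, and it shows that the oxan-2-yl ring and its hydrogen-bond acceptor are not required for a low number. Nothing available explains the size of this step. Open, as far as these compounds go, is whether cyclopropyl or a longer alkyl chain at this place keeps the low number. Also open, from the compounds shown here alone, is whether the step carries over to compounds with isopropoxy on the aromatic carbon.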